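The source may report more compounds than this note shows. Statements on the series, on what has been measured and on what is new or still open speak of the compounds shown alone.

Compound 1 `C#CCOc1ccc2c(=O)c(-c3cc(OC)c(OC)cc3OC)coc2c1`: > 10000 nM (a limit)
Compound 2 `COc1cc(OC)c(-c2coc3cc(OCc4ccccc4)ccc3c2=O)cc1OC`: 9750 nM
Compound 3 `COc1cc(OC)c(-c2coc3cc(OCc4ccc([N+](=O)[O-])cc4)ccc3c2=O)cc1OC`: > 10000 nM (a limit)

All three values come from a functional assay on HUVEC cells (Homo sapiens) for antiproliferative activity, read by MTT assay, with a stated time of 24 h; a higher number here means a weaker inhibitor, a lower number a stronger inhibitor. Compound 3 gives only a limit, > 10000 nM, not a number. Much of this small set rests on (the limit of > 10000 nM in this assay, at which 2 of the 3 values shown sit).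

The next compound, compound 4 `COc1cc(OC)c(-c2coc3cc(OCc4cccc(F)c4)ccc3c2=O)cc1OC`, has not been measured. It carries 3-fluorophenyl in place of 4-nitrophenyl on a saturated chain carbon bound to an oxygen on an aromatic ring.

Among the measured compounds shown here, three measured steps bear on this change. The closest is an at least 1.0-fold higher number from compound 2 to compound 3 (0.01 log units; that floor lies within the scatter), where nitro replaces hydrogen on an aromatic carbon. The second is an at least 1.0-fold lower number from compound 1 to compound 2 (0.01 log units; that floor lies within the scatter), and the third is a step that the two limits leave unreadable from compound 1 to compound 3. None of them shows a change beyond the scatter. Compound 2, with phenyl in the same place, gives 9750 nM, so no step beyond the scatter is expected in this assay.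

The expected step is a number no higher from compound 3 to compound 4 (the limit leaves the size open). For compound 4 the estimate is 10000 nM, with an expected range from 4000 nM to 25000 nM.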

Compound 4, half-maximal inhibitory concentration: 5300 nM
For compound 4 the middle estimate is 1.9-fold (0.28 log units) above the measured one; low and high end bracket the measured number.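

In this assay, 3-fluorophenyl gives a second measured number at this place, on a saturated chain carbon bound to an oxygen on an aromatic ring, so two groups there can now be compared directly, not only through limits. The step between these two measured numbers is a 1.8-fold lower number from compound 2 to compound 4 (0.26 log units; within the scatter), so this pair cannot be told apart. The other two steps start from limits and give only floors, an at least 1.8-fold lower number from compound 3 to compound 4 (0.27 log units; that floor lies within the scatter) and an at least 1.8-fold lower number from compound 1 to compound 4 (0.27 log units; that floor lies within the scatter), so neither shows a change beyond the scatter.

On these data alone, whether an amine, a carboxylic acid or a longer chain at this place would move the number beyond the scatter stays open. The set still holds values that give no number to compare, and its reading rests on one ceiling: the limit of > 10000 nM in this assay, at which 2 of the 4 values shown sit.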